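The source may report more compounds than this note shows. Statements on the series, on what has been measured and on what is new or still open speak of the compounds shown alone.

Measured compounds:
- compound 1 `O=C(Nc1cccnc1)c1ccccc1OCc1c(F)cccc1Cl`: 1500 nM
- compound 2 `O=C(Nc1cccnc1)c1ccccc1OCc1cccc(Cl)c1F`: 3100 nM

Among the measured compounds shown here, in an assay on lysate for inhibition of phosphatidylcholine:ceramide cholinephosphotransferase 2 (Homo sapiens), read by HPLC, with stated times of 30 min and 2 h (on this read-out higher numbers stand for weaker inhibition and lower numbers for stronger inhibition), compound 2 gives the higher of the two numbers; the single step, a 2.1-fold higher number from compound 1 to compound 2 (0.32 log units; beyond the scatter), places it beyond the scatter from compound 1. Compound 3 `Cc1cccc(C)c1COc1ccccc1C(=O)Nc1cccnc1` differs from compound 2 by 2,6-dimethylphenyl in place of 3-chloro-2-fluorophenyl on a saturated chain carbon bound to an oxygen on an aromatic ring. For the measured compounds named here, no measured step swaps halogens for methyl groups, so only the step between compound 1 and compound 2 bears on it, and only loosely. A modest change is expected, a 1.6-fold lower number from compound 2 to compound 3 (0.19 log units; within the scatter), in either direction, so compound 3 is estimated at 2000 nM, within 700 nM to 6000 nM.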

Compound 3, half-maximal inhibitory concentration: 890 nM
For compound 3 the middle estimate is 2.2-fold (0.35 log units) above the measured one, within the range that was stated.
By their numbers in this assay, from the lowest: compounds 3 and 1 (each within the scatter of the next); then compound 2.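

In this assay, this position accepts a ring carrying only carbon substituents: the change to 2,6-dimethylphenyl gives a 3.5-fold lower number from compound 2 to compound 3 (0.54 log units; beyond the scatter). Against the other halogenated ring, the same group gives a 1.7-fold lower number from compound 1 to compound 3 (0.23 log units; within the scatter), so halogens are not required here for the numbers seen with 2-chloro-6-fluorophenyl. Nothing available explains this difference between the steps.

Still open, going by these compounds, is how an unsubstituted phenyl ring or a 2,6-dimethoxyphenyl group would behave at this position. A ring bearing an amine or a carboxylic acid also remains untested among the compounds shown.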